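Aryl variation on the piperazine nitrogen of a triazine series

The source may hold more compounds than are shown below. What is called first, only, known or untested is meant among the compounds shown, and "the series" means these compounds.

Of the compounds shown here, three sharing one core have been measured in a functional assay on DU-145 cells (Homo sapiens) for cytotoxicity, read by sulforhodamine B assay, with a stated time of 48 h; a higher number here means a weaker inhibitor of growth, a lower number a stronger inhibitor of growth. Compound 1 `N#Cc1ccc(Nc2nc(Oc3ccnc4ccccc34)nc(N3CCN(c4ccc(F)cc4)CC3)n2)cc1C(F)(F)F` reaches only the limit of this assay, > 100000 nM. Compound 2 `CC(=O)N1CCN(c2nc(Nc3ccc(C#N)c(C(F)(F)F)c3)nc(Oc3ccnc4ccccc34)n2)CC1` gives 75100 nM in this assay. Compound 3 `COc1ccc(N2CCN(c3nc(Nc4ccc(C#N)c(C(F)(F)F)c4)nc(Oc4ccnc5ccccc45)n3)CC2)cc1` likewise sits at the limit, > 100000 nM. Compound 3 thus stands at the ceiling of this assay, as shown by the limit of > 100000 nM in this assay, at which 2 of the 3 values shown sit. The step that the two limits leave unreadable from compound 1 to compound 3 cannot be read, and an at least 1.3-fold higher number from compound 2 to compound 3 (0.12 log units; that floor lies within the scatter) is a small rise. Compound 4 `N#Cc1ccc(Nc2nc(Oc3ccnc4ccccc34)nc(N3CCN(c4cccc(Cl)c4Cl)CC3)n2)cc1C(F)(F)F` differs from compound 3 by 2,3-dichlorophenyl in place of 4-methoxyphenyl on an amine nitrogen in a ring. Neither measured step shows a clear move off the limit for an aryl on that ring nitrogen, so the step that the limit leaves unreadable from compound 3 to compound 4 is expected to stay within the scatter. Compound 4 is therefore estimated at 120000 nM, with a range from 40000 nM to 300000 nM, most probably again a limit.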

Compound 4, concentration for 50% growth inhibition: > 100000 nM
Compound 4 gave a limit, no number; the forecaster's own chance of this, stated with the estimate: 70%; the middle value is on the limit's open side.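

In this assay, a chlorine-bearing aryl, 2,3-dichlorophenyl, on the amine nitrogen in the ring also gives a limit in compound 4, so the steps to compound 4 from compound 1 and compound 3 cannot be read. Against the acetyl group, the change gives an at least 1.3-fold higher number from compound 2 to compound 4 (0.12 log units; that floor lies within the scatter), which does not separate aryl from acetyl at this position. The ceiling now holds three of the aryl-free and aryl compounds together: the limit of > 100000 nM in this assay, at which 3 of the 4 values shown sit.

Any ranking among the aryl groups stays open. Also open, on these data alone, is whether a carboxylic acid or a longer chain ending in an amine on that ring nitrogen would give a readable number.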